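Adding a second chloro to the core of compound 3

This account rests on a few compounds, and the source may have more. Where it says the series, first, only, none or still open, it means among the compounds named here.

Measured compounds:
compound 1, `ClCc1ccc(Cn2cnc3c(Cl)ncnc32)cc1`, 6760 nM
compound 2, `ClCc1ccccc1Cn1cnc2c(Cl)nc(Cl)nc21`, 3630 nM
compound 3, `ClCc1ccc(Cn2cnc3ncnc(Cl)c32)cc1`, 3160 nM

In a functional assay on HOP-62 cells (Homo sapiens) for cytotoxicity, read by sulforhodamine B assay, with a stated time of 48 h (a higher number here means a weaker inhibitor of growth, a lower number a stronger inhibitor of growth), compound 3 gives the lowest of the three numbers. Compound 2 stands closest to it, within the usual scatter, so no order can be read between these two. Compound 1 stands furthest from compound 3, beyond the scatter.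

Compound 4, `ClCc1ccc(Cn2cnc3nc(Cl)nc(Cl)c32)cc1`, has not yet been measured in this assay. It differs from compound 3 in one place: chloro in place of hydrogen on an aromatic carbon.

Within the data shown here, no pair of measured compounds shows this change directly. Compound 2, which also carries two chloro groups on its core, sits within the scatter of compound 3, so the step of a 1.1-fold lower number from compound 3 to compound 4 (0.02 log units; within the scatter) is expected to be small, in no firm direction. For compound 4 the estimated value is 3000 nM, with a range from 1200 nM to 7500 nM.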

Compound 4, concentration for total growth inhibition: 3890 nM
Beside the measured number, compound 4's estimate is 1.3-fold (0.11 log units) below it; the range from low to high includes it.
By their numbers in this assay, from the lowest: compounds 3, 2, 4 and 1 (each within the scatter of the next, the first and the last beyond it).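

In this assay, chloro in place of hydrogen on an aromatic carbon between two ring nitrogen atoms gives a 1.2-fold higher number from compound 3 to compound 4 (0.09 log units; within the scatter) and so leaves no readable change in growth inhibition. Among these compounds, this is the first direct view of this change, as no earlier pair differed in one place, and it shows that this position takes a chloro without a shift beyond the scatter. Nothing measured bears on why the step is this small.

From the compounds shown here alone, whether an amine or a methoxy group at this position would move the number beyond the scatter stays open. So does whether the same chloro step would read alike on compound 1.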